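The source may report more compounds than this note shows. Statements on the series, on what has been measured and on what is new or still open speak of the compounds shown alone.

Compound 1 `Nc1scc(CN2CCN(c3ccc(Cl)c(C(F)(F)F)c3)CC2)c1C(=O)c1ccc(Cl)cc1` carries a 4-chloro-3-(trifluoromethyl)phenyl on an amine nitrogen in a ring and is the anchor for the next step in the series. In a functional assay on CHO cells with adenosine receptor A1 (Homo sapiens) as the target, read by cAMP accumulation and immunoassay, with a stated time of 6 min, tested at 0.01 uM (on this read-out lower numbers stand for a stronger effect and higher numbers for a weaker effect at the one concentration tested), compound 1 gives -2.5%. Two further members have numbers in this assay. Compound 2 `Nc1scc(CN2CCC(c3ccc(Cl)cc3)CC2)c1C(=O)c1ccc(Cl)cc1` gives 0% in this assay, and compound 3 `Nc1scc(CN2CCN(c3cccc(F)c3)CC2)c1C(=O)c1cccc(C(F)(F)F)c1` gives -11% in this assay. On these three numbers compound 1 sits second of three; its gap to compound 2 lies within the usual scatter, and so does its gap to compound 3, so the three cannot be told apart. All three sit in the same narrow band, consistent with little effect at the single concentration tested. For the measured compounds named here, no pair of measured compounds differs in only one place, so no measured step is available to guide the next change.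

Compound 4 `Nc1scc(CN2CCN(c3c(F)cccc3F)CC2)c1C(=O)c1ccc(Cl)cc1` has not been measured in this assay. Its difference from compound 1 is 2,6-difluorophenyl in place of 4-chloro-3-(trifluoromethyl)phenyl on an amine nitrogen in a ring. With the measured set showing no spread beyond the scatter, the step of a number 0.5 percentage points lower from compound 1 to compound 4 (within the scatter) is expected to be none beyond the scatter. Compound 4 is estimated at -3% in this assay, with a range from -13% to 7%.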

Compound 4, a percentage reported as activity, at one concentration (the size of the read-out at that concentration, not a potency): -12%
Beside the measured number, compound 4's estimate is 9 percentage points above it; the measured number falls inside the stated range.
By their numbers in this assay, from the lowest: compounds 4, 3, 1 and 2 (each within the scatter of the next, the first and the last beyond it).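

In this assay, the pair of compound 1 and compound 4 gives the series its first reading at a single place: 2,6-difluorophenyl in place of 4-chloro-3-(trifluoromethyl)phenyl on an amine nitrogen in a ring gives a number 9.5 percentage points lower from compound 1 to compound 4 (within the scatter) and so does not separate the two groups. This position therefore accepts a change to a group with fewer heavy atoms, the loss of chlorine and a different fluorine count without a step beyond the scatter, at least for this one pair and at the single concentration tested. No supporting measurement bears on this step, and the result carries no explanation.

What the compounds shown leave open is whether any group at this position can produce a step beyond the scatter, for example a carboxylic acid, a primary amine or a longer alkyl chain in place of the aromatic ring. For the compounds shown here, also open is whether the two aryl groups would remain indistinguishable at other concentrations, since a single-concentration read-out gives no potency for either compound.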